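Swapping pyridin-3-yl while every value sits at a limit

The compounds below may be only part of what the source reports. "The series", "measured", "known", "first", "only" and "open" are said of these compounds alone.

Measured in an ADME assay on MRC5 cells (Homo sapiens) for cytotoxicity, read by fluorescence and resazurin assay, with a stated time of 3 days; a higher number here means a weaker inhibitor, a lower number a stronger inhibitor:
Compound 1 `Cc1cccc(Oc2cccc(CN3CCC(n4cc(C)c(=O)[nH]c4=O)CC3)c2)c1`: > 64000 nM
Compound 2 `Cc1cn(C2CCN(Cc3cccc(Oc4ccc(F)c(F)c4)c3)CC2)c(=O)[nH]c1=O`: > 64000 nM
Compound 3 `Cc1cn(C2CCN(Cc3cccc(Oc4cccnc4)c3)CC2)c(=O)[nH]c1=O`: > 64000 nM

Each entry is a limit of the assay and not a number. Compound 3 stands at > 64000 nM, which is likewise a limit. All the readings so far sit at the limit of > 64000 nM in this assay, at which 3 of the 3 values shown sit, so the three compounds cannot be ranked against one another.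

The next compound is compound 4 `Cc1cn(C2CCN(Cc3cccc(Oc4cccc(C(F)(F)F)c4)c3)CC2)c(=O)[nH]c1=O`, which differs from compound 3 as follows: 3-(trifluoromethyl)phenyl in place of pyridin-3-yl on an oxygen on an aromatic ring. In words, 3-(trifluoromethyl)phenyl takes the place of pyridin-3-yl on an oxygen on an aromatic ring.

Three measured changes at this same place bear on it: a step that the two limits leave unreadable from compound 1 to compound 2, then a step that the two limits leave unreadable from compound 1 to compound 3, and a step that the two limits leave unreadable from compound 2 to compound 3. None of them has a size that can be read. Those steps offer no sign of a shift, so no step beyond the usual scatter is expected, and another limit is the likeliest report from this assay here. The expected change is a number no higher from compound 3 to compound 4 (the limit leaves the size open) in size, with no direction favoured.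

For compound 4 the estimate is 64000 nM, with an expected range from 32000 nM to 100000 nM as the likely span.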

Compound 4, half-maximal inhibitory concentration: 12400 nM
Beside the measured number, compound 4's estimate is 5.2-fold (0.71 log units) above it, outside the stated range (below it).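

In this assay, this place on the oxygen now shows that the group it carries can move the reading: 3-(trifluoromethyl)phenyl in place of pyridin-3-yl gives an at least 5.1-fold lower number from compound 3 to compound 4 (0.71 log units; beyond the scatter), and in place of 3,4-difluorophenyl it gives an at least 5.1-fold lower number from compound 2 to compound 4 (0.71 log units; beyond the scatter). Even the exchange of trifluoromethyl for methyl on an aromatic carbon, with the rest of the molecule unchanged, gives an at least 5.1-fold lower number from compound 1 to compound 4 (0.71 log units; beyond the scatter). From the compounds shown here alone, the steps among compound 1, compound 2 and compound 3 cannot be read, and each of the new steps starts from a limit, so its true size stays open and only compound 4 has a number: the limit of > 64000 nM in this assay, at which 3 of the 4 values shown sit.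

The compounds shown do not tell whether trifluoromethyl is special or whether a chlorine, a methoxy group or a nitrile on the same phenyl ring would give a similar reading. They also leave open how an amine or a carboxylic acid at this place would read, and how far compound 1, compound 2 and compound 3 truly lie from compound 4.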